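The source may report more compounds than this note shows. Statements on the series, on what has been measured and on what is new or still open speak of the compounds shown alone.

Compound 3 `CC(=O)OC[C@H]1O[C@H](OC(C)=O)[C@H](NC(=O)[C@H](C)NCCC2OCC(C)(C)CO2)[C@@H](OC(C)=O)[C@@H]1OC(C)=O` stands second highest of the three numbers in a functional assay on the whole organism (Ear, strain ICR) for inhibition, with Mus musculus as the target, with stated times of 30 min and 2 h, at a dose of 10 umol/kg by the oral route (on this read-out lower numbers stand for less inhibition and higher numbers for more inhibition at the one dose given (going by the name of the read-out)), and all three lie within the scatter of one another: compound 1 `CC[C@H](C)[C@H](NCCC1OCC(C)(C)CO1)C(=O)N[C@H]1[C@@H](OCc2ccccc2)O[C@H](COCc2ccccc2)[C@@H](OCc2ccccc2)[C@@H]1OCc1ccccc1` gives 81.6%, compound 2 `C[C@H](NCCC1OCC(C)(C)CO1)C(=O)N[C@H]1[C@@H](OCc2ccccc2)O[C@H](COCc2ccccc2)[C@@H](OCc2ccccc2)[C@@H]1OCc1ccccc1` gives 90.3%, and compound 3 gives 84.2%. Compound 4 `CC(=O)OC[C@H]1O[C@H](OC(C)=O)[C@H](NC(=O)[C@H](CC(C)C)NCCC2OCC(C)(C)CO2)[C@@H](OC(C)=O)[C@@H]1OC(C)=O` differs from compound 3 by isopropyl in place of hydrogen on a saturated chain carbon, two bonds along the chain from an amine nitrogen and a carbonyl carbon. Within the data shown here, the only measured step that bears on this is a number 8.7 percentage points higher from compound 1 to compound 2 (within the scatter), where the alkyl group on the carbon bound to the amine nitrogen and the carbonyl carbon was exchanged with no effect beyond the scatter. A step of a number 0.2 percentage points lower from compound 3 to compound 4 (within the scatter) is therefore expected, none beyond the scatter. For compound 4 an estimate of 84% is made, with a range from 70% to 95%.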

Compound 4, a percentage reported as inhibition, in the whole organism at one dose (the size of the read-out at that dose, not a potency): 86.6%
Beside the measured number, compound 4's estimate is 2.6 percentage points below it, within the range that was stated.
By their numbers in this assay, from the lowest: compounds 1, 3, 4 and 2 (each within the scatter of the next).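

In this assay, isopropyl in place of hydrogen on a saturated chain carbon, two bonds along the chain from an amine nitrogen and a carbonyl carbon, gives a number 2.4 percentage points higher from compound 3 to compound 4 (within the scatter). The earlier step varied this alkyl group only on the core of compound 1; this one shows that, on the core of compound 3 as well, the methyl to isobutyl exchange stays within the scatter. Nothing available explains this result. On these data alone, whether an amine or a carboxylic acid on this side chain would stay within the scatter remains open.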